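Removing one methoxy group: expected cell toxicity

The source may report more compounds than this note shows. Statements on the series, on what has been measured and on what is new or still open speak of the compounds shown alone.

Compound 2 `COc1cc(-c2cc(/C=C/C(=O)c3ccc(N)cc3)[nH]n2)cc(OC)c1OC` gives 73200 nM in a functional assay on NCI-H23 cells (Homo sapiens) for inhibition, read by sulforhodamine B assay, with a stated time of 48 h; on this read-out higher numbers stand for lower toxicity in this test and lower numbers for higher toxicity in this test. Compound 1 `COc1ccc(-c2cc(/C=C/C(=O)c3ccc(N)cc3)[nH]n2)cc1` gives 68400 nM in this assay, and these two numbers lie within the scatter of each other. Compound 3 `COc1cc(-c2cc(/C=C/C(=O)c3ccc(F)c(F)c3)[nH]n2)cc(OC)c1OC` returns only a limit of the assay in this assay, > 100000 nM. The step of an at least 1.3-fold higher number from compound 2 to compound 3 (0.13 log units; that floor lies within the scatter) is thus known only as a floor (the limit of > 100000 nM in this assay, at which 1 of the 3 values shown sits). Compound 4 `COc1ccc(-c2cc(/C=C/C(=O)c3ccc(N)cc3)[nH]n2)cc1OC` differs from compound 2 by hydrogen in place of methoxy on an aromatic carbon. Going by the values given here, no measured step covers this change directly; the nearest comparison is compound 1, whose 68400 nM sits within the scatter of compound 2. In this assay the expected step is a 1.0-fold lower number from compound 2 to compound 4 (0.02 log units; within the scatter), that is, none beyond the scatter. Compound 4 is therefore estimated at 70000 nM, with a range from 35000 nM to 140000 nM.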

Compound 4, concentration lethal to 50% of the cells: 95600 nM
The estimate for compound 4 lay 1.4-fold (0.14 log units) below the measured number; measured number inside the range.
By their numbers in this assay, from the lowest: compounds 1, 2 and 4 (each within the scatter of the next). At a limit, above all of these: compound 3.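

In this assay, replacing this methoxy with hydrogen gives a 1.3-fold higher number from compound 2 to compound 4 (0.12 log units; within the scatter) and placing a methoxy on the same aromatic carbon of compound 1 gives a 1.4-fold higher number from compound 1 to compound 4 (0.15 log units; within the scatter) as a second reading of the change. Both steps stay within the scatter, so on this series the position, ortho to a methoxy group and meta to a large group, holds either hydrogen or methoxy without a readable effect on the number.

From the compounds shown here alone, whether an amine or a carboxylic acid on this carbon would produce a step beyond the scatter remains open. One value in this set is only a limit: the limit of > 100000 nM in this assay, at which 1 of the 4 values shown sits.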